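A few compounds are considered here, and "the series" means these few. Any claim that something is new, unique, unknown or untested is made for them only; others in the source may bear on it.

Measured in an ADME assay on Huh-7 cells (Homo sapiens) for cytotoxicity, with a stated time of 72 h; a higher number here means that more compound is tolerated, a lower number that less compound is tolerated:
- compound 1 `CCC(C)n1nc(-c2cccs2)c(O)c(C2=NS(=O)(=O)c3cc(NS(C)(=O)=O)ccc3N2)c1=O`: > 33000 nM (a limit)
- compound 2 `CC(C)Cn1nc(-c2cccs2)c(O)c(C2=NS(=O)(=O)c3cc(NS(C)(=O)=O)ccc3N2)c1=O`: > 1000 nM (a limit)

Compound 2 has no numerical value in this assay, only the limit > 1000 nM. The other value in the series is also a limit.

Compared with compound 2, compound 3 `CS(=O)(=O)Nc1ccc2c(c1)S(=O)(=O)N=C(c1c(O)c(-c3cccs3)nn(CCC3CCCC3)c1=O)N2` carries cyclopentylmethyl in place of isopropyl on a saturated chain carbon bound to an aromatic nitrogen.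

Among the compounds with values here, the only measured step bearing on this change is a step that the two limits leave unreadable from compound 1 to compound 2, for isobutyl in place of sec-butyl on an aromatic nitrogen. It gives neither a size nor a direction, so no firm shift can be predicted in this assay. The estimate therefore leans on compound 1, whose limit is > 33000 nM, and another limit is the likeliest report. The expected step is a step that the limit leaves unreadable from compound 2 to compound 3. For compound 3 the estimated value is 15000 nM, with an expected range of 3000 nM to 50000 nM.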

Compound 3, half-maximal cytotoxic concentration: > 1000 nM
Compound 3 ended at the assay's limit (the forecaster's own chance of this, stated with the estimate: 75%); the middle value does not contradict the limit.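

In this assay compound 3 gives > 1000 nM, which is a limit. No step can be read among compound 1, compound 2 and compound 3, as all three values are limits. From the compounds shown here alone, it remains open whether the group on the aromatic nitrogen shifts cytotoxicity at all.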